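Does one inverted stereocentre change compound 3?

The compounds below may be only part of what the source reports. "The series", "measured", "known", "first", "only" and "open" are said of these compounds alone.

- compound 1 `Cc1cc(C)c(CN2CCc3c(Cl)cc([C@H](CO)[C@H]4CCCO4)c(Cl)c3C2=O)c(=O)[nH]1` gives 430000 nM
- compound 2 `Cc1cc(C)c(CN2CCc3c(Cl)cc([C@@H](CO)[C@@H]4CCOC4)c(Cl)c3C2=O)c(=O)[nH]1` gives 537000 nM
- compound 3 `Cc1cc(C)c(CN2CCc3c(Cl)cc([C@H](C)CO)c(Cl)c3C2=O)c(=O)[nH]1` gives 131000 nM

In a physicochemical assay for solubility, measured as kinetic solubility (on this read-out lower numbers stand for lower solubility and higher numbers for higher solubility), compound 3 has the lowest of the three numbers, at 131000 nM. Compound 4 `Cc1cc(C)c(CN2CCc3c(Cl)cc([C@@H](C)CO)c(Cl)c3C2=O)c(=O)[nH]1` is its stereo partner: the two compounds have the same atoms and bonds and differ only in configuration as drawn: 1 of 1 stereo elements differ; a stereocentre at a saturated chain carbon is drawn S in compound 3 and R in compound 4. The stereocentre at a saturated chain carbon is drawn S in compound 3 and R in compound 4. Going by the values given here, no measured pair differs in configuration alone. The closest guide is a 1.2-fold higher number from compound 1 to compound 2 (0.10 log units; within the scatter), where one eight-atom ring-bearing group replaces another. The larger 3.3-fold lower number from compound 1 to compound 3 (0.52 log units; beyond the scatter) and a 4.1-fold lower number from compound 2 to compound 3 (0.61 log units; beyond the scatter) both involve losing the ring, which does not happen here. The expected result is therefore no change beyond the scatter, in neither direction, with an estimated 1.1-fold higher number from compound 3 to compound 4 (0.03 log units; within the scatter). Compound 4 is estimated at 140000 nM, with an expected range from 65000 nM to 290000 nM.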

Compound 4, solubility: 143000 nM
Compound 4: the middle estimate sits 1.0-fold (0.01 log units) below what was measured; measured number inside the range.
By their numbers in this assay, from the lowest: compounds 3 and 4 (each within the scatter of the next); then compounds 1 and 2 (each within the scatter of the next).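

In this assay, going by these compounds alone, inverting the stereocentre at the saturated chain carbon gives a 1.1-fold higher number from compound 3 to compound 4 (0.04 log units; within the scatter), the first reading of configuration on its own, and it is a direct one because of a single fact: the fact that compounds 3 and 4 differ only in the configuration as drawn. The gap to the ring-bearing compounds stands with either drawn configuration, at a 3.8-fold lower number from compound 2 to compound 4 (0.57 log units; beyond the scatter) and a 3.0-fold lower number from compound 1 to compound 4 (0.48 log units; beyond the scatter). The compounds shown leave open whether inversion stays this small with oxolan-2-yl or oxolan-3-yl on that carbon. From the compounds shown here alone, how an amine in place of the methyl would read also remains open.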